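The compounds below may be only part of what the source reports. "The series", "measured", "known", "first", "only" and "open" are said of these compounds alone.

Series notes. Compound 1 `CNc1cc(Oc2ccc(NC(=O)Nc3ccccc3)cc2)ncn1` carries a hydrogen at the position under study. Among the compounds with values here, in an assay on isolated protein for inhibition of serine/threonine-protein kinase TNNI3K (Homo sapiens) (a lower number here means a stronger inhibitor, a higher number a weaker inhibitor), compound 1 gives 6300 nM, the higher of the two numbers measured so far. Within the data shown here, the only other measured member, compound 2 `CNc1cc(Oc2c(F)cc(NC(=O)Nc3cccc(C(F)(F)F)c3)cc2F)ncn1`, gives 20 nM in this assay; compound 2 differs from compound 1 in more than one place, so no single step can be drawn between them, but the gap between their two values lies well beyond the usual scatter and shows how far a member of this series can move. Compound 3 `CNc1cc(Oc2ccc(NC(=O)Nc3cccc(C(C)(F)F)c3)cc2)ncn1` is the next to be measured. Relative to compound 1 the change is 1,1-difluoroethyl in place of hydrogen on an aromatic carbon. The entering group is a near relative of the trifluoromethyl that compound 2 carries, although compound 3 lacks the additional fluorines present in compound 2. A sizeable step toward a lower number, beyond the scatter, is expected, yet one that stops short of the value of compound 2. For compound 3 the estimate in this assay is 400 nM with a range of 100 nM to 1500 nM. This corresponds to an expected step of a 16-fold lower number from compound 1 to compound 3 (1.20 log units; beyond the scatter).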

Compound 3, half-maximal inhibitory concentration: 40 nM
Compound 3: the middle estimate sits 10-fold (1.00 log units) above what was measured, outside the stated range (below it).
By their numbers in this assay, from the lowest: compounds 2 and 3 (each within the scatter of the next); then compound 1.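

In this assay, 1,1-difluoroethyl in place of hydrogen on an aromatic carbon, meta to a large group, gives a 160-fold lower number from compound 1 to compound 3 (2.20 log units; beyond the scatter), a large step. The rest of compound 3 matches compound 1, so this step can be assigned to a single replacement, which the earlier pair, differing in more than one place, could not show, and this position is clearly one at which the value in this series can move a long way. No measurement available here explains the size of the step, so its cause remains unassigned.

On these data alone, it remains open whether the step is specific to 1,1-difluoroethyl or would also appear with methyl, chlorine, trifluoromethyl, methoxy or an amine at the same carbon of the otherwise unchanged compound 1. Also open, as far as these compounds go, are what the additional fluorines of compound 2 contribute when introduced alone, and whether 1,1-difluoroethyl would give a step of similar size at another carbon of the same ring.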